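A few compounds are considered here, and "the series" means these few. Any claim that something is new, unique, unknown or untested is made for them only; others in the source may bear on it.

Measured so far:
- Compound 1 `COc1cc(/C=C2\CN(C)C/C(=C\c3ccc(Cl)cc3)C2=O)cc(OC)c1`: 11200 nM
- Compound 2 `COc1cc(/C=C2\CN(C)C/C(=C\c3ccc(Cl)c(Cl)c3)C2=O)cc(OC)c1OC`: 13500 nM
- Compound 3 `CN1C/C(=C\c2ccc(F)cc2)C(=O)/C(=C/c2cccc([N+](=O)[O-])c2)C1`: 6250 nM

In a functional assay on HeLa cells (Homo sapiens) for cytotoxicity, read by MTT assay, with a stated time of 24 h (a higher number here means a weaker inhibitor, a lower number a stronger inhibitor), compound 3 stands at 6250 nM. That number lies within the scatter of compound 1 at 11200 nM, while compound 2 at 13500 nM reads higher than compound 3, beyond the scatter.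

The next compound is compound 4 `CN1C/C(=C\c2cccc([N+](=O)[O-])c2)C(=O)/C(=C/c2ccc(Cl)c(Cl)c2)C1`, with 3,4-dichlorophenyl in place of 4-fluorophenyl on a double-bonded chain carbon bound to a double-bonded ring carbon. Among the compounds with values here, no two measured compounds differ in one place only, so the data show no direct precedent for this change. Compound 2 at 13500 nM also carries 3,4-dichlorophenyl, but it differs from compound 4 elsewhere as well and offers only a loose guide. Little movement is expected in this assay, none beyond the scatter, and the estimated step is a 1.1-fold higher number from compound 3 to compound 4 (0.05 log units; within the scatter). For compound 4 the expected value is 7000 nM, with an estimated range from 3200 nM to 14000 nM.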

Compound 4, half-maximal inhibitory concentration: 9120 nM
Compound 4: the middle estimate sits 1.3-fold (0.11 log units) below what was measured; the range from low to high includes it.
By their numbers in this assay, from the lowest: compounds 3, 4, 1 and 2 (each within the scatter of the next, the first and the last beyond it).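

In this assay, within the data shown here, this is the first pair that differs in one place only: 3,4-dichlorophenyl in place of 4-fluorophenyl on a double-bonded chain carbon bound to a double-bonded ring carbon gives a 1.5-fold higher number from compound 3 to compound 4 (0.16 log units; within the scatter). The exchange of these two halogen-bearing phenyl groups therefore leaves the number within the scatter, with the rest of the molecule held constant. The earlier compounds shown here could not show this, since each of them differs from the others in more than one place.

From the compounds shown here alone, whether an amine, a carboxylic acid or a longer chain on this carbon would move the number beyond the scatter stays open, as does whether the same exchange gives a similar step on a different remainder of the molecule. Nothing measured here bears on why the step has this size.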